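The compounds below may be only part of what the source reports. "The series", "measured", "known", "first", "only" and "open" are said of these compounds alone.

Values in a functional assay on L1210 cells (Mus musculus) for inhibition; on this read-out higher numbers stand for weaker inhibition and lower numbers for stronger inhibition:
- Compound 1 `CC(C)CN(NC(=O)OCc1ccccc1)C(=O)CN(Cc1ccccc1)NC(=O)CBr`: 1300 nM
- Compound 2 `CC(C)CN(NC(=O)OCc1ccccc1)C(=O)CN(Cc1ccccc1)NC(=O)Cc1cccc(Br)c1`: 30000 nM
- Compound 3 `CC(C)CN(CC(=O)N(CC(C)C)NC(=O)OCc1ccccc1)/N=C/c1cccc(B(O)O)c1`: 21200 nM

Compound 3, at 21200 nM, lies within the scatter of compound 2 and has a clearly higher number than compound 1.

Next is compound 4 `CC(C)CN(NC(=O)OCc1ccccc1)C(=O)CN(Cc1ccccc1)/N=C/c1cccc(B(O)O)c1`, with phenyl in place of isopropyl on a saturated chain carbon bound to an amine nitrogen.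

For the measured compounds named here, no measured step covers this change. The only one, a 23-fold higher number from compound 1 to compound 2 (1.36 log units; beyond the scatter), is large but concerns a different exchange, 3-bromophenyl in place of bromo, so it gives no size to carry over. Without such a step, no shift beyond the scatter is expected in this assay. The expected step is a 1.2-fold lower number from compound 3 to compound 4 (0.07 log units; within the scatter). Compound 4 is estimated at 18000 nM, with an expected range of 6000 nM to 50000 nM.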

Compound 4, half-maximal inhibitory concentration: 16200 nM
Compound 4: the middle estimate sits 1.1-fold (0.05 log units) above what was measured, within the range that was stated.
By their numbers in this assay, from the lowest: compound 1; then compounds 4, 3 and 2 (each within the scatter of the next).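

Phenyl in place of isopropyl on a saturated chain carbon bound to an amine nitrogen gives no shift beyond the scatter in this assay (a 1.3-fold lower number from compound 3 to compound 4 (0.12 log units; within the scatter)), so this position tolerates the exchange of isobutyl for benzyl with the boron-bearing group in place. Compound 4 stays within the scatter of the 3-bromophenyl compound (a 1.9-fold lower number from compound 2 to compound 4 (0.27 log units; within the scatter)) but remains well apart from the bromo compound (a 12-fold higher number from compound 1 to compound 4 (1.10 log units; beyond the scatter)). No measurement on hand explains these steps.

On these data alone, whether phenethyl in place of benzyl, or a carboxylic acid in place of the boron-bearing group, would move the number remains open.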